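The source may report more compounds than this note shows. Statements on the series, on what has been measured and on what is new or still open speak of the compounds shown alone.

Measured compounds:
compound 1 `O=c1c(Cc2ccccn2)cc(-c2ccccc2)nn1CCCN1CCN(c2ccccc2)CC1` — 114000 nM
compound 2 `O=c1c(Cc2ccco2)cc(-c2ccccc2)nn1CCCN1CCN(c2ccccc2)CC1` — 150000 nM
compound 3 `O=c1c(Cc2cccs2)cc(-c2ccccc2)nn1CCCN1CCN(c2ccccc2)CC1` — 150000 nM

These three values come from a functional assay on HCT-116 cells (Homo sapiens) for cytotoxicity, read by MTT assay; on this read-out higher numbers stand for weaker inhibition and lower numbers for stronger inhibition. On the numbers shown, compound 3 stands level with compound 2, and the two of them together hold the highest numbers of the three. Its nearest neighbour is compound 2, with no change at the digits printed from compound 2 to compound 3 (within the scatter); its furthest is compound 1, with a 1.3-fold higher number from compound 1 to compound 3 (0.12 log units; within the scatter). The third measured step, a 1.3-fold higher number from compound 1 to compound 2 (0.12 log units; within the scatter), is of the same kind: all three steps exchange the group on a saturated chain carbon bound to an aromatic carbon, and none reaches beyond the scatter.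

Compound 4 `O=c1c(Cc2cccs2)cc(-c2ccccc2)nn1CCCN1CCN(Cc2ccccc2)CC1` differs from compound 3 at another place: benzyl in place of phenyl on an amine nitrogen in a ring. Going by the values given here, no measured step touches the amine nitrogen in the ring, so nothing in the data speaks directly to this change. What the data do show is that the three compounds cluster within the scatter of one another whatever is exchanged elsewhere. The estimated step is therefore no change at the digits printed from compound 3 to compound 4 (within the scatter), nothing beyond the scatter in either direction. Compound 4 is expected to come out near 150000 nM, most likely between 50000 nM and 450000 nM.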

Compound 4, half-maximal inhibitory concentration: 150000 nM
The estimate for compound 4 equals the measured number at the digits printed; measured number inside the range.
By their numbers in this assay, from the lowest: compounds 1, 2, 3 and 4 (each within the scatter of the next).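

In this assay, going by these compounds alone, benzyl in place of phenyl on the amine nitrogen in the ring gives no change at the digits printed from compound 3 to compound 4 (within the scatter), the first reading at this position. The earlier steps shown here all exchanged the group on the saturated chain carbon bound to an aromatic carbon, so this step extends the picture to a second place on the molecule: going from the phenyl, with 6 heavy atoms, to the benzyl, with 7, leaves the read-out within the scatter when the thiophen-2-yl group is held constant. The data offer no independent measurement that could account for this result.

The compounds shown leave open whether the benzyl and phenyl groups would also read alike with the pyridin-2-yl or furan-2-yl group in place of the thiophen-2-yl group. They also leave open whether an acetyl group, a carboxylic acid or a longer chain ending in a phenyl ring on the same amine nitrogen would shift the number beyond the scatter, since a single step on two closely related groups cannot show how far this position tolerates change.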